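Swapping chloro for methoxy on a pyrazole carboxamide triazole series

The source may hold more compounds than are shown below. What is called first, only, known or untested is meant among the compounds shown, and "the series" means these compounds.

Measured compounds:
compound 1, `O=C(NCc1cn(Cc2ccc(Cl)cc2)nn1)c1cn(-c2ccccc2)nc1-c1ccccc1`, 600 nM;
compound 2, `COc1ccc(Cn2cc(CNC(=O)c3cn(-c4ccccc4)nc3-c3ccccc3)nn2)cc1`, 6900 nM;
compound 3, `O=C(NCc1cn(Cc2ccc(F)cc2)nn1)c1cn(-c2ccccc2)nc1-c1ccc(Cl)cc1`, 2800 nM.

In a functional assay on HeLa cells (Homo sapiens) for antiproliferative activity, read by sulforhodamine B assay, with a stated time of 48 h (a higher number here means a weaker inhibitor of growth, a lower number a stronger inhibitor of growth), compound 1 gives 600 nM, and compound 2 gives 6900 nM. The two differ by methoxy in place of chloro on an aromatic carbon, and this one change made a 12-fold higher number from compound 1 to compound 2 (1.06 log units; beyond the scatter). Compound 3 gives 2800 nM; how its core differs from that of compound 1 is not broken down here.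

Compound 4, `COc1ccc(-c2nn(-c3ccccc3)cc2C(=O)NCc2cn(Cc3ccc(F)cc3)nn2)cc1`, has not yet been measured. It differs from compound 3 by methoxy in place of chloro on an aromatic carbon. The same kind of change was made from compound 1 to compound 2, but there it read, one bond further out, 4-chlorobenzyl to 4-methoxybenzyl, whereas here it reads 4-chlorophenyl to 4-methoxyphenyl, so it is the same kind of change and not the same one. Going by the values given here, because a 12-fold higher number from compound 1 to compound 2 (1.06 log units; beyond the scatter) was large, a step toward a higher number is expected for compound 4 as well, though a smaller one, since the ring carrying the change is a different one and only two such examples exist. Compound 4 is therefore estimated at 7000 nM, between 2500 nM and 20000 nM, which means an expected 2.5-fold higher number from compound 3 to compound 4 (0.40 log units; beyond the scatter).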

Compound 4, concentration for 50% growth inhibition: 500 nM
The estimate for compound 4 lay 14-fold (1.15 log units) above the measured number, outside the stated range (below it).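

In this assay, methoxy in place of chloro on an aromatic carbon gave a 5.6-fold lower number from compound 3 to compound 4 (0.75 log units; beyond the scatter), the opposite direction to the earlier swap. Set side by side, the two results show that this kind of change did not carry over from one core to the other in either direction or size: the same change on two cores in this assay, a 12-fold higher number (1.06 log units; beyond the scatter) from compound 1 to compound 2 and a 5.6-fold lower number (0.75 log units; beyond the scatter) from compound 3 to compound 4, 64-fold (1.81 log units) apart, beyond the scatter of two such steps. They show that the outcome of this swap cannot be assumed from one core to the next in this series, but they do not show why, as the ring carrying the change differs between the two pairs, as does the rest of the structure, and two pairs establish no rule.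

The compounds shown leave open whether the direction of the step follows the ring that carries the change or the remainder of the core. They also leave open how a hydroxy group or a dimethylamino group in the same place would compare with chloro and methoxy.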